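A few compounds are considered here, and "the series" means these few. Any claim that something is new, unique, unknown or untested is made for them only; others in the source may bear on it.

Working notes on the aminothiophene series, a functional assay on CHO cells with adenosine receptor A1 (Homo sapiens) as the target, read by cAMP accumulation and immunoassay, with a stated time of 6 min, tested at 1 uM; a lower number here means a stronger effect, a higher number a weaker effect of the compound at the concentration tested.

Of the compounds shown here, two carry a number so far. Compound 1, `Nc1scc(CN2CCN(c3ccc(OC(F)(F)F)cc3)CC2)c1C(=O)c1ccc(Cl)cc1`, gives -51% in this assay. Compound 2, `Nc1scc(CN2CCN(c3cccc(F)c3F)CC2)c1C(=O)c1ccc(Cl)cc1`, gives -66% in this assay. Within the data shown here, of the two numbers compound 2 stands lowest, the nearest being compound 1, and the only measured step, a number 15 percentage points lower from compound 1 to compound 2 (beyond the scatter), is the exchange of the aryl group on the amine nitrogen in the ring.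

Compound 3, `Nc1scc(CN2CCN(c3c(F)cc(F)cc3F)CC2)c1C(=O)c1ccc(Cl)cc1`, is not yet measured. It differs from compound 2 in one place: 2,4,6-trifluorophenyl in place of 2,3-difluorophenyl on an amine nitrogen in a ring. Among the measured compounds shown here, the single known step bears on this only loosely, since it exchanged a trifluoromethoxy-bearing phenyl for a difluorophenyl, whereas here one fluorinated phenyl replaces another on the same amine nitrogen in the ring. For the measured compounds named here, that step was modest; no step between two fluorinated phenyls has been measured. The expectation is therefore a step of no more than the scatter in this assay, in no settled direction, so for compound 3 the estimated step is a number 4 percentage points higher from compound 2 to compound 3 (within the scatter). Compound 3 is thus expected to give about -62% in this assay, within a range from -80% to -44%.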

Compound 3, a percentage reported as activity, at one concentration (the size of the read-out at that concentration, not a potency): -56%
Compound 3: the middle estimate sits 6 percentage points below what was measured; low and high end bracket the measured number.
By their numbers in this assay, from the lowest: compounds 2, 3 and 1 (each within the scatter of the next, the first and the last beyond it).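

In this assay the exchange of one fluorinated phenyl for another on the amine nitrogen in the ring, 2,4,6-trifluorophenyl in place of 2,3-difluorophenyl, gives a number 10 percentage points higher from compound 2 to compound 3 (within the scatter) and so does not separate the two groups, even with the added fluorine. The same group in place of 4-(trifluoromethoxy)phenyl gives a number 5 percentage points lower from compound 1 to compound 3 (within the scatter) and also stays unresolved, so compound 3 cannot be set apart from either of the other two, although the earlier exchange gave a number 15 percentage points lower from compound 1 to compound 2 (beyond the scatter) here. A fluorinated phenyl in place of the trifluoromethoxy-bearing phenyl therefore holds no general gain at this position: compound 2 stands apart from compound 1, while compound 3 goes against any such pattern, and nothing on hand explains these numbers.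

Open, on these data alone, is how this single-concentration read-out responds to a group of another kind on this nitrogen, such as an unsubstituted phenyl, a pyridine ring or a benzyl group. Also open, as far as these compounds go, is whether these steps persist when the chlorine of the shared core gives way to a methoxy group.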